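From Propyl to Methyl on the Shared Core

The source may hold more compounds than are shown below. What is called first, only, known or untested is meant among the compounds shown, and "the series" means these compounds.

Among the measured compounds shown here, in a functional assay on HCT-116 cells (Homo sapiens) for cytotoxicity, read by MTT assay, with a stated time of 72 h (on this read-out higher numbers stand for weaker inhibition and lower numbers for stronger inhibition), compound 1 `COc1ncc(-c2ccc3nc(NC(=O)NCC(=O)N4CCCC4)nn3c2)cc1NS(=O)(=O)c1ccc(F)cc1` gives 140 nM and compound 2 `CCCNC(=O)Nc1nc2ccc(-c3cnc(OC)c(NS(=O)(=O)c4ccc(F)cc4)c3)cn2n1` gives 150 nM, so compound 2 stands level with its only measured neighbour. Compound 3 `CNC(=O)Nc1nc2ccc(-c3cnc(OC)c(NS(=O)(=O)c4ccc(F)cc4)c3)cn2n1` carries hydrogen in place of ethyl on a saturated chain carbon bound to an amide-type nitrogen, turning propyl to methyl (hydrogen in place of ethyl on a saturated chain carbon bound to an amide-type nitrogen). For the measured compounds named here, the one measured step at this kind of place, a 1.1-fold higher number from compound 1 to compound 2 (0.03 log units; within the scatter), stayed within the scatter, so no step beyond the scatter is expected in this assay. The expected change is a 1.1-fold higher number from compound 2 to compound 3 (0.05 log units; within the scatter). For compound 3 the estimate is 170 nM, with an expected range of 70 nM to 420 nM.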

Compound 3, half-maximal inhibitory concentration: 180 nM
Compound 3: the middle estimate sits 1.1-fold (0.02 log units) below what was measured; the range from low to high includes it.
By their numbers in this assay, from the lowest: compounds 1, 2 and 3 (each within the scatter of the next).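

Shortening propyl to methyl gave a 1.2-fold higher number from compound 2 to compound 3 (0.08 log units; within the scatter) in this assay, and hydrogen in place of (pyrrolidin-1-yl)carbonyl gave a 1.3-fold higher number from compound 1 to compound 3 (0.11 log units; within the scatter) on the same read-out. On a saturated chain carbon bound to an amide-type nitrogen, this assay therefore does not tell apart any of the chain ends shown, even the shortest. Nothing available gives a reason for this flat response. On these data alone, whether a chain ending in an amine or a carboxylic acid, or one longer than propyl, would also leave the number unmoved remains open.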